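Methoxy Replaced by Fluoro: Expectation for Compound 3

The source may report more compounds than this note shows. Statements on the series, on what has been measured and on what is new or still open speak of the compounds shown alone.

Measured compounds:
compound 1, `COc1ccc(/C=C/C(=O)Nc2cc(C(=O)c3cc(OC)c(OC)c(OC)c3)ccc2OC)cc1`, 8700 nM
compound 2, `COc1ccc(/C=C/C(=O)Nc2cc(C(=O)c3cc(OC)c(OC)c(OC)c3)cc(OC)c2OC)cc1`, 9400 nM

Both compounds were tested in a functional assay on B16 cells (Mus musculus) for cytotoxicity, read by MTT assay, with a stated time of 72 h; a lower number here means a stronger inhibitor, a higher number a weaker inhibitor. Compound 2 shows the highest of the two numbers; its nearest neighbour is compound 1, and the difference is within the scatter, so the two cannot be ordered. For the measured compounds named here, the only measured step, a 1.1-fold higher number from compound 1 to compound 2 (0.03 log units; within the scatter), adds a methoxy on an aromatic carbon and changes the number by no more than the scatter.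

Compound 3, `COc1cc(C(=O)c2cc(OC)c(OC)c(OC)c2)cc(NC(=O)/C=C/c2ccc(F)cc2)c1OC`, is not yet measured. It differs from compound 2 by fluoro in place of methoxy on an aromatic carbon. Going by the values given here, no measured step concerns this position or this exchange, so the step from compound 1 to compound 2 offers no direct guide; it only shows that a change elsewhere on the shared core left the number unmoved. Among the compounds with values here, with that as the sole precedent, the step from compound 2 to compound 3 is expected to stay near zero, a 1.0-fold lower number from compound 2 to compound 3 (0.02 log units; within the scatter), though with wide uncertainty. Compound 3 is therefore estimated at 9000 nM in this assay, within a range of 3000 nM to 27000 nM.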

Compound 3, half-maximal inhibitory concentration: 900 nM
Estimate against measurement, compound 3: 10-fold (1.00 log units) above; the whole stated range lies above it.
By their numbers in this assay, from the lowest: compound 3; then compounds 1 and 2 (each within the scatter of the next).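

In this assay, for the compounds shown here, the exchange of 4-methoxyphenyl for 4-fluorophenyl gives a 10-fold lower number from compound 2 to compound 3 (1.02 log units; beyond the scatter), whereas the only earlier step, a 1.1-fold higher number from compound 1 to compound 2 (0.03 log units; within the scatter), stayed within the scatter. The earlier pair showed one change on the shared core that left the number unmoved, while this pair shows that the number does respond to what stands on this aromatic carbon, para to a large group, and that swapping methoxy for fluoro there is enough to produce a large step. Nothing in the available data accounts for the size of this step.

The compounds shown leave open whether hydrogen, chloro, trifluoromethyl or an amine on this same carbon would give a number close to that of compound 3 at 900 nM or close to that of compound 2 at 9400 nM, so a single exchange cannot separate the departure of the methoxy from the arrival of the fluoro. They also leave open whether the same exchange would produce a step of similar size on the core of compound 1, which carries one methoxy fewer.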